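A few compounds are considered here, and "the series" means these few. Any claim that something is new, unique, unknown or untested is made for them only; others in the source may bear on it.

Measured so far in a functional assay on A549 cells (Homo sapiens) for antiproliferative activity; a lower number here means a stronger inhibitor of growth, a higher number a weaker inhibitor of growth:
- compound 1 `c1ccc(-c2cc(-c3ccsc3)cc(-c3ccccn3)n2)nc1` gives 0.62 ug/mL
- compound 2 `c1ccc(-c2cc(-c3ccccn3)nc(-c3ccccn3)c2)cc1` gives 0.56 ug/mL
- compound 3 `c1ccc(-c2cc(-c3ccoc3)cc(-c3ccccn3)n2)nc1` gives 0.08 ug/mL

Compound 3 holds the lowest number of the three, with a 7.0-fold lower number from compound 2 to compound 3 (0.85 log units; beyond the scatter) from its nearest neighbour and a 7.8-fold lower number from compound 1 to compound 3 (0.89 log units; beyond the scatter) from its furthest. The next structure, compound 4 `c1ccc(-c2cc(-c3cccs3)cc(-c3ccccn3)n2)nc1` carries thiophen-2-yl in place of furan-3-yl on an aromatic carbon. Among the measured compounds shown here, no thiophen-2-yl compound has been measured, so the closest guide is compound 1, which carries thiophen-3-yl. Going from that group to furan-3-yl gave a 7.8-fold lower number from compound 1 to compound 3 (0.89 log units; beyond the scatter) while phenyl in the same place gave a 1.1-fold lower number from compound 1 to compound 2 (0.04 log units; within the scatter) so only compound 3 stands apart. Leaving furan-3-yl is therefore expected to give back most of that gap, towards a higher number and weaker growth inhibition. The expected size of the change is a 5.0-fold higher number from compound 3 to compound 4 (0.70 log units; beyond the scatter) and it remains uncertain. For compound 4 the estimate is 0.4 ug/mL with an expected range of 0.12 ug/mL to 1.1 ug/mL in this assay.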

Compound 4, concentration for 50% growth inhibition: 0.44 ug/mL
Compound 4: the middle estimate sits 1.1-fold (0.04 log units) below what was measured, and the stated range covers the measured number.
By their numbers in this assay, from the lowest: compound 3; then compounds 4, 2 and 1 (each within the scatter of the next).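

In this assay, thiophen-2-yl on this aromatic carbon, opposite the ring nitrogen, does not hold what furan-3-yl gave, with a 5.5-fold higher number from compound 3 to compound 4 (0.74 log units; beyond the scatter) as the step away from that group. Against the other two, a 1.4-fold lower number from compound 1 to compound 4 (0.15 log units; within the scatter) and a 1.3-fold lower number from compound 2 to compound 4 (0.10 log units; within the scatter) both stay within the scatter, so shifting the attachment point on the thiophene changes nothing readable here, and compound 3 alone stands apart among the four. Nothing available explains why furan-3-yl differs from phenyl and from both thiophenes.

The compounds shown leave open whether furan-2-yl would match furan-3-yl at this place, which would show whether the low number follows the furan ring or its attachment point. They also leave open whether an amine or a carboxylic acid on the furan ring would keep the number of compound 3.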